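An Aryl Swap on a Compound at the Limit

The source may report more compounds than this note shows. Statements on the series, on what has been measured and on what is new or still open speak of the compounds shown alone.

In an ADME assay on Raji cells (Homo sapiens) for cytotoxicity, read by CellTiter-Glo and resazurin assay, with a stated time of 72 h (on this read-out higher numbers stand for an effect only at larger amounts of compound and lower numbers for an effect already at smaller amounts), compound 1 (`COc1ccc(F)c(-c2ccc(C(=O)N(Cc3cccc(OCCCCCC(=O)O)c3)C(C)C)cc2)c1`) gives > 26000 nM as a limit and not as a number. Compound 2 (`CCOC(=O)CCCCCOc1cccc(CN(C(=O)c2ccc(-c3ccc4[nH]ccc4c3)cc2)C(C)C)c1`) likewise gives > 26000 nM as a limit only. The record therefore stands at the limit of > 26000 nM in this assay, at which 2 of the 2 values shown sit, and compound 2 has no number of its own. Compound 3 (`CCOC(=O)CCCCCOc1cccc(CN(C(=O)c2ccc(-c3cc(OC)ccc3F)cc2)C(C)C)c1`) differs from compound 2 in one place, with 2-fluoro-5-methoxyphenyl in place of 1H-indol-5-yl on an aromatic carbon. Compound 1 carries the same 2-fluoro-5-methoxyphenyl group and still reports > 26000 nM as a limit. No measured step sizes this change. The expected change is a number no higher from compound 2 to compound 3 (the limit leaves the size open) in this assay, and nothing beyond the usual scatter is expected. For compound 3 the estimate is 26000 nM with an expected range from 9000 nM to 50000 nM and the assay may well report a limit again.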

Compound 3, half-maximal effective concentration: > 26000 nM
Compound 3 ended at the assay's limit (the forecaster's own chance of this, stated with the estimate: 75%); the middle value lies on the limit itself.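

In this assay, compound 3 gives a limit and not a number, so neither step to it, from compound 1 or from compound 2, can be read: the limit of > 26000 nM in this assay, at which 3 of the 3 values shown sit. The compounds shown leave open at what concentration any of them would show an effect, and whether either change makes any difference.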